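The source may hold more compounds than are shown below. What is called first, only, known or untested is meant among the compounds shown, and "the series" means these compounds.

Working notes on the series in a functional assay on microsomes from liver (Rattus norvegicus, strain Wistar) for inhibition, with a stated time of 15 min; on this read-out higher numbers stand for weaker inhibition and lower numbers for stronger inhibition. Of the compounds shown here, two have been measured so far. Compound 1 `COc1cc(C2CC(c3cc4ccccc4o3)=NN2C(=O)Nc2ccc(F)cc2)ccc1O` gives 125000000 nM, and compound 2 `COc1ccc(NC(=O)N2N=C(c3cc4ccccc4o3)CC2c2ccc(O)c(OC)c2)cc1` gives 29000000 nM, the lower of the two numbers. Among the compounds with values here, the only measured step is a 4.3-fold lower number from compound 1 to compound 2 (0.63 log units; beyond the scatter); it is methoxy in place of fluoro on an aromatic carbon, modest but beyond the scatter.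

The next compound to place is compound 3 `COc1cc(C2CC(c3cc4ccccc4o3)=NN2C(=O)Nc2ccc([N+](=O)[O-])cc2)ccc1O`. Its difference from compound 2 is nitro in place of methoxy on an aromatic carbon. Within the data shown here, the change falls at the same site as the measured step, so that step is the one guide available. Among the measured compounds shown here, it is thin evidence, since no nitro compound has yet been measured and fluoro is a different group. Methoxy in compound 2 went with the lower number, 29000000 nM, so losing it should move the number back up by a similar modest amount in this assay. The expected step is a 2.8-fold higher number from compound 2 to compound 3 (0.44 log units; beyond the scatter). Compound 3 is estimated at 80000000 nM, with an expected range of 20000000 nM to 300000000 nM.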

Compound 3, half-maximal inhibitory concentration: 113000000 nM
Compound 3: the middle estimate sits 1.4-fold (0.15 log units) below what was measured, and the stated range covers the measured number.
By their numbers in this assay, from the lowest: compound 2; then compounds 3 and 1 (each within the scatter of the next).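

In this assay, nitro in place of methoxy on the aromatic carbon para to a large group gives a 3.9-fold higher number from compound 2 to compound 3 (0.59 log units; beyond the scatter) and so adds a second comparison in which the methoxy compound carries the lower number. The other new comparison, nitro in place of fluoro at the same carbon, is a 1.1-fold lower number from compound 1 to compound 3 (0.04 log units; within the scatter) and lies within the scatter, so these two groups cannot be told apart in this read-out, and among the three compounds only the methoxy compound stands apart. No measurement is available that could explain this separation, and the numbers alone show only that it exists.

On these data alone, whether the lower number is particular to methoxy or extends to other groups remains open, and an amine or an ethoxy group on the same aromatic carbon would help to settle this. As far as these compounds go, all three compounds also share the rest of the core, so it is equally open whether the separation of methoxy from fluoro and nitro would persist with a change elsewhere in the structure, such as a carboxylic acid on the other aromatic ring.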